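From ethoxycarbonyl to benzyloxycarbonyl on the shared core

This account rests on a few compounds, and the source may have more. Where it says the series, first, only, none or still open, it means among the compounds named here.

In a functional assay on A2780 cells (Homo sapiens) for antiproliferative activity, read by MTT assay, with a stated time of 48 h (on this read-out lower numbers stand for stronger inhibition of growth and higher numbers for weaker inhibition of growth), compound 3 (`CCOC(=O)N1N=C(c2ccc(OC)cc2)CC1c1cc(OC)c(OC)c(OC)c1`) gives 9270 nM as its reading. Compound 2 (`COC(=O)N1N=C(c2ccc(OC)cc2)CC1c1cc(OC)c(OC)c(OC)c1`) gives 5000 nM on the same read-out, and the two values lie within the scatter of each other. Compound 1 (`COc1cc(C2CC(c3ccccc3)=NN2C(=O)OCc2ccccc2)cc(OC)c1OC`) gives > 10000 nM in this assay and that value is a limit, not a number.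

Compound 4 (`COc1ccc(C2=NN(C(=O)OCc3ccccc3)C(c3cc(OC)c(OC)c(OC)c3)C2)cc1`) differs from compound 3 by phenyl in place of methyl on a saturated chain carbon bound to an oxygen next to a carbonyl group and so has phenyl in place of methyl on a saturated chain carbon bound to an oxygen next to a carbonyl group. The same difference reads ethoxycarbonyl to benzyloxycarbonyl.

Among the measured compounds shown here, one measured step bears on this place: a 1.9-fold higher number from compound 2 to compound 3 (0.27 log units; within the scatter) for methyl in place of hydrogen. That step is small, but it is a much smaller change than the one at hand, so it gives only weak guidance. Compound 1 also carries benzyloxycarbonyl, and with the limit of > 10000 nM in this assay, at which 1 of the 3 values shown sits, close to the reading of compound 3, a limit is a real possibility for compound 4. No step beyond the scatter is expected in this assay on this evidence.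

The expected value for compound 4 is 10000 nM with an estimated range of 4000 nM to 25000 nM in this assay overall. This estimate corresponds to a 1.1-fold higher number from compound 3 to compound 4 (0.03 log units; within the scatter) as the expected step.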

Compound 4, concentration for 50% growth inhibition: > 10000 nM
Compound 4 was reported as a limit; the forecaster's own chance of this, stated with the estimate: 45%; the middle value lies on the limit itself.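

Compound 4 gives > 10000 nM in this assay, and that value is a limit, not a number. Phenyl in place of methyl at this place can therefore be stated only as a floor, an at least 1.0-fold higher number from compound 3 to compound 4 (0.03 log units; that floor lies within the scatter), and phenyl in place of hydrogen likewise, an at least 2.0-fold higher number from compound 2 to compound 4 (0.30 log units; that floor lies within the scatter), so neither change is shown to go beyond the scatter, though a larger step is not excluded. The step from compound 1 to compound 4 cannot be read, as both values are limits, and benzyloxycarbonyl gives no number on either compound: the limit of > 10000 nM in this assay, at which 2 of the 4 values shown sit.

The comparison at this place on the shared core covers only hydrogen, methyl and phenyl, and none of the readable steps is shown to go beyond the scatter. Going by these compounds, what a longer chain such as butyl, or a chain ending in an amine or a carboxylic acid, would read here remains open, as does whether any group at this place gives a number clearly lower than that of compound 2 at 5000 nM.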